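Azetidine oxadiazoles: methyl to fluoro on the phenyl ring

The source may hold more compounds than are shown below. What is called first, only, known or untested is meant among the compounds shown, and "the series" means these compounds.

Measured compounds:
compound 1 `Cc1cccc(-c2noc(C3CN(S(=O)(=O)c4ccc(Cl)cc4)C3)n2)c1` — an assay on HEK293 cells for negative allosteric modulation of metabotropic glutamate receptor 5 (Homo sapiens), read by FLIPR; a higher number here means a weaker inhibitor, a lower number a stronger inhibitor: 1100 nM
compound 2 `Cc1cccc(-c2noc(C3CN(C(=O)C4CCC(C(F)(F)F)CC4)C3)n2)c1` — this assay: > 10000 nM

For the measured compounds named here, only two compounds have numbers so far. In this assay compound 1 gives 1100 nM. Compound 2 returns > 10000 nM in this assay; this is a limit of the assay and not a number. Compound 2 therefore stands at the limit of > 10000 nM in this assay, at which 1 of the 2 values shown sits. Going by the values given here, no single-point step between compound 1 and compound 2 is computed, so the two values are taken only as they stand.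

Compound 3 `O=C(C1CCC(C(F)(F)F)CC1)N1CC(c2nc(-c3cccc(F)c3)no2)C1` is the next compound to be measured in this assay. It differs from compound 2 by fluoro in place of methyl on an aromatic carbon, that is, 3-methylphenyl to 3-fluorophenyl, with the rest of the molecule unchanged.

Because compound 2 sits at the limit of > 10000 nM in this assay, at which 1 of the 2 values shown sits, the starting point for compound 3 is itself unresolved. The step from compound 2 to compound 3 is expected to be a step that the limit leaves unreadable from compound 2 to compound 3, that is, nothing clearly beyond the scatter. Compound 3 is accordingly estimated at 15000 nM, with a range from 4000 nM to 50000 nM, and a fair chance that the assay again reports only a limit.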

Compound 3, half-maximal inhibitory concentration: > 10000 nM
Compound 3: only a limit was reported; the forecaster's own chance of this, stated with the estimate: 65%; the middle value lies beyond the limit too.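

Compound 2 and compound 3 are both reported only as a limit in this assay, so no step can be read for the change from 3-methylphenyl to 3-fluorophenyl: the limit of > 10000 nM in this assay, at which 2 of the 3 values shown sit.

The compounds shown leave open whether 3-methylphenyl and 3-fluorophenyl differ at all on a compound that returns a number rather than a limit.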